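Removing the amino from the aryl group of compound 2

A few compounds are considered here, and "the series" means these few. Any claim that something is new, unique, unknown or untested is made for them only; others in the source may bear on it.

Compound 2 `Cc1nc2c3ccccc3ccc2c2nc3c(ccc4ccccc43)c(-c3ccccc3N)c12` carries the 2-aminophenyl on the shared core and in a functional assay on HCT-116 cells (Homo sapiens) for cytotoxicity, read by MTT assay, with a stated time of 48 h (a higher number here means a weaker inhibitor, a lower number a stronger inhibitor), gives 4760 nM, the lowest of the two numbers at hand. Compound 1 `Cc1nc2c3ccccc3ccc2c2nc3c(ccc4ccccc43)c(-c3cccnc3)c12`, bearing pyridin-3-yl at the same aromatic carbon, gives 34200 nM in this assay. For compound 3 `Cc1nc2c3ccccc3ccc2c2nc3c(ccc4ccccc43)c(C)c12`, with methyl at that carbon, this assay reports only a limit, > 80000 nM; this is the limit of > 80000 nM in this assay, at which 1 of the 3 values shown sits.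

The measured steps run a 7.2-fold lower number from compound 1 to compound 2 (0.86 log units; beyond the scatter), an at least 2.3-fold higher number from compound 1 to compound 3 (0.36 log units; beyond the scatter) and an at least 16-fold higher number from compound 2 to compound 3 (1.22 log units; beyond the scatter). Both aryl groups therefore give lower numbers than methyl, and the 2-aminophenyl gives the lowest.

Compound 4 `Cc1nc2c3ccccc3ccc2c2nc3c(ccc4ccccc43)c(-c3ccccc3)c12` differs from compound 2 by hydrogen in place of amino on an aromatic carbon. Among the compounds with values here, no measured pair shows exactly this change. The steps to compound 1 and compound 3 bear on it indirectly: a plain phenyl keeps the aromatic ring that methyl lacks, but loses the amino that sets compound 2 apart from compound 1. A higher number than compound 2 is expected, of modest size, with compound 4 most likely falling between compound 2 and compound 1.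

Compound 4 is therefore estimated at 15000 nM, between 5000 nM and 45000 nM, a step of a 3.2-fold higher number from compound 2 to compound 4 (0.50 log units; beyond the scatter).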

Compound 4, half-maximal inhibitory concentration: > 80000 nM
Compound 4 was reported as a limit (the forecaster's own chance of this, stated with the estimate: 5%); at least 5.3-fold (0.72 log units) between middle value and limit.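

In this assay the amino, on an aromatic carbon ortho to a large group, proves decisive for the number of compound 2, which is lost on going to the plain phenyl, with an at least 16-fold higher number from compound 2 to compound 4 (1.22 log units; beyond the scatter). The earlier reading that an aryl group in itself gives a lower number than methyl does not hold for phenyl: compound 4 gives > 80000 nM, which is a limit of the assay. Pyridin-3-yl also gives a lower number than phenyl, with an at least 2.3-fold higher number from compound 1 to compound 4 (0.36 log units; beyond the scatter), while the step between compound 3 and compound 4 cannot be read, since both compounds sit at the same limit: the limit of > 80000 nM in this assay, at which 2 of the 4 values shown sit.

The compounds shown leave open whether another group at the same aromatic carbon, such as a hydroxyl, a methoxy or a dimethylamino, would keep the number of compound 2 or lose it. From the compounds shown here alone, the true size of the step to phenyl also stays open, and so does whether the order of these groups holds in any cell line other than the one used here.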